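Swapping One Ring for a Pyridinyloxy Group

This account rests on a few compounds, and the source may have more. Where it says the series, first, only, none or still open, it means among the compounds named here.

Of the compounds shown here, three built on one shared core have been tested in a functional assay on isolated protein for agonist activity at Free fatty acid receptor 1 (Homo sapiens), read by HTRF and inositol phosphate accumulation, with a stated time of 60 min; on this read-out lower numbers stand for an effect already at smaller amounts and higher numbers for an effect only at larger amounts of compound. Compound 1 `CCOc1ccc(F)c(-c2ccc(OCCCC(=O)O)cc2)c1` gives 3190 nM. For compound 2 `O=C(O)CCCOc1ccc(-c2ccccc2C(F)(F)F)cc1` the assay reports only a limit, > 9950 nM. For compound 3 `O=C(O)CCCOc1ccc(-c2cc(-[n+]3ccsc3)ccc2Cl)cc1` the assay likewise reports only a limit, > 9950 nM, so compound 3 stands at the weak end of what has been shown, at the limit of > 9950 nM in this assay, at which 2 of the 3 values shown sit. Compound 4 `O=C(O)CCCOc1ccc(-c2cc(Oc3cccnc3)ccc2Cl)cc1` has not yet been measured and differs from compound 3 in one place: a group of 7 heavy atoms (5 carbon, 1 nitrogen, 1 oxygen; one six-membered aromatic ring with 1 hetero atom) in place of a group of 5 heavy atoms (3 carbon, 1 nitrogen, 1 sulfur; one five-membered aromatic ring with 2 hetero atoms), on an aromatic carbon. The entering (pyridin-3-yl)oxy group sits on an aromatic carbon of a six-membered aromatic ring of carbon only, meta to a large group and para to a chloro group. No step between measured compounds has been determined, so the size of this change can only be judged from the spread of what has been shown, with compound 1 at 3190 nM and compounds 2 and 3 at the weak end. Compound 4 is expected to come nearer to compound 1, with an estimated value of 2500 nM, between 400 nM and 9950 nM. For compound 4 this expectation means a step of an at least 3.9-fold lower number from compound 3 to compound 4 (0.59 log units; beyond the scatter), judged to lie beyond the scatter.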

Compound 4, half-maximal effective concentration: > 9950 nM
Compound 4 was reported as a limit (the forecaster's own chance of this, stated with the estimate: 30%); at least 3.9-fold (0.59 log units) between middle value and limit.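

Within the data shown here, compound 3 and compound 4 both report only a limit rather than a number, so no step between them can be read: the limit of > 9950 nM in this assay, at which 3 of the 4 values shown sit.

From the compounds shown here alone, whether exchanging the five-membered ring group for (pyridin-3-yl)oxy changes the activity of this core in this assay remains open.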